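Swapping the Bicyclic Amide Partner of an Inactive Sulfone

The source may hold more compounds than are shown below. What is called first, only, known or untested is meant among the compounds shown, and "the series" means these compounds.

The measured compounds:
compound 1, `O=C(NCc1ccc(S(=O)(=O)c2ccccc2)cc1)c1cc2ncccc2s1`: > 10000 nM
compound 2, `O=C(Nc1ccc(S(=O)(=O)N2CCCCC2)cc1)c1cc2cnccc2[nH]1`: > 10000 nM
compound 3, `O=C(NCc1ccc(S(=O)(=O)c2ccc(F)c(F)c2)cc1)c1cc2cnccc2[nH]1`: 14 nM

All three were tested in a functional assay on A2780 cells (Homo sapiens) for inhibition, read by sulforhodamine B assay, with a stated time of 72 h; on this read-out higher numbers stand for weaker inhibition and lower numbers for stronger inhibition. Compound 1 sits at the limit of the assay, so its value of > 10000 nM is a limit and not a number. Compound 2 likewise reaches only the limit, > 10000 nM. Compound 3, which carries a fused bicyclic amide with a ring nitrogen-hydrogen and a difluorinated aryl sulfone, gives a measured number in this assay, 14 nM. Among the values shown, compound 1 therefore stands with the limits, where (the limit of > 10000 nM in this assay, at which 2 of the 3 values shown sit).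

Compound 4, `O=C(NCc1ccc(S(=O)(=O)c2ccccc2)cc1)c1ccc2nncn2c1`, is not yet measured. It differs from compound 1 in one place: a group of 9 heavy atoms (6 carbon, 3 nitrogen; one five-membered aromatic ring with 3 hetero atoms, one six-membered aromatic ring with 1 hetero atom) in place of a group of 9 heavy atoms (7 carbon, 1 nitrogen, 1 sulfur; one five-membered aromatic ring with 1 hetero atom, one six-membered aromatic ring with 1 hetero atom), on a carbonyl carbon. For the measured compounds named here, no measured pair in this set separates the effect of such a change, so the size of the step cannot be read from the data. Since compound 1 itself only reaches the limit, compound 4 is expected to remain at or near that limit, with the step that the limit leaves unreadable from compound 1 to compound 4 estimated to lie within the scatter. Compound 4 is thus estimated at 15000 nM, with a range from 3000 nM to 60000 nM.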

Compound 4, half-maximal inhibitory concentration: > 10000 nM
Compound 4 gave a limit, no number; the forecaster's own chance of this, stated with the estimate: 70%; the middle value is on the limit's open side.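

In this assay compound 4 gives only a limit, as compound 1 does, so no step between compound 1 and compound 4 can be read: the limit of > 10000 nM in this assay, at which 3 of the 4 values shown sit.

The compounds shown leave open whether exchanging these two groups on a carbonyl carbon changes inhibition at all, as no pair differing only there gives two measured numbers.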